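The source may hold more compounds than are shown below. What is called first, only, known or untested is meant among the compounds shown, and "the series" means these compounds.

Measured compounds in an assay on a cell-free system (plasma) for inhibition of Dipeptidyl peptidase 4 (Rattus norvegicus), read by fluorescence; on this read-out lower numbers stand for stronger inhibition and higher numbers for weaker inhibition:
- compound 1, `CN1CCN([C@@H]2CN[C@H](C(=O)N3CCSC3)C2)CC1`, compound 1 gives 81.1 nM
- compound 2, `O=C([C@@H]1C[C@H](N2CCN(c3ccc(Br)cc3)CC2)CN1)N1CCSC1`, compound 2 gives 9 nM
- compound 3, `COc1ccc(N2CCN([C@@H]3CN[C@H](C(=O)N4CCSC4)C3)CC2)cc1`, compound 3 gives 16.9 nM

Among these three numbers compound 3 holds the second highest; its nearest neighbour is compound 2, with a 1.9-fold higher number from compound 2 to compound 3 (0.27 log units; within the scatter), while compound 1 lies furthest, with a 4.8-fold lower number from compound 1 to compound 3 (0.68 log units; beyond the scatter).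

Compound 4, `O=C([C@@H]1C[C@H](N2CCN(c3ccc(Cl)cn3)CC2)CN1)N1CCSC1`, carries the change (5-chloropyridin-2-yl in place of 4-methoxyphenyl on an amine nitrogen in a ring). Going by the values given here, the steps that bear on this change are those in which the methyl on the ring amine nitrogen was exchanged for an aryl group: a 9.0-fold lower number from compound 1 to compound 2 (0.95 log units; beyond the scatter) and a 4.8-fold lower number from compound 1 to compound 3 (0.68 log units; beyond the scatter). Between the two aryl groups themselves the difference was small, as a 1.9-fold higher number from compound 2 to compound 3 (0.27 log units; within the scatter) shows. An aryl group with a halogen, compound 2, gave the lowest number seen, so a halogen-bearing ring on the same nitrogen is expected to land close to compounds 2 and 3.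

Compound 4 is therefore estimated at 12 nM, within 5 nM to 30 nM. This expected step, a 1.4-fold lower number from compound 3 to compound 4 (0.15 log units; within the scatter), is not expected to exceed the scatter.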

Compound 4, half-maximal inhibitory concentration: 3.1 nM
Beside the measured number, compound 4's estimate is 3.9-fold (0.59 log units) above it, outside the stated range (below it).
By their numbers in this assay, from the lowest: compound 4; then compounds 2 and 3 (each within the scatter of the next); then compound 1.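

In this assay, the 5-chloropyridin-2-yl group on the amine nitrogen in the ring moves the number beyond the scatter relative to both earlier aryl groups, with a 5.5-fold lower number from compound 3 to compound 4 (0.74 log units; beyond the scatter) and a 2.9-fold lower number from compound 2 to compound 4 (0.46 log units; beyond the scatter), although those two aryl groups lay within the scatter of each other. This position therefore still responds to a change of aryl group, and the full step from the methyl group reaches a 26-fold lower number from compound 1 to compound 4 (1.42 log units; beyond the scatter). Nothing measured here accounts for this difference between the carbon-only ring and the ring with one hetero atom.

Compound 4 differs from compounds 2 and 3 in both the ring atoms and the substituent, so the contribution of each remains unresolved. A plain pyridin-2-yl group and a chlorophenyl group would be needed to separate the ring nitrogen from the chlorine.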